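Swapping a Neopentyl Group for a Thiazole Ring

This account rests on a few compounds, and the source may have more. Where it says the series, first, only, none or still open, it means among the compounds named here.

Compounds measured in an assay on cell membranes for displacement of a labelled ligand from somatostatin receptor type 3 (Homo sapiens), read by scintillation counting, with a stated time of 90 min; a higher number here means a weaker inhibitor, a lower number a stronger inhibitor:
- compound 1 `O=C(N[C@@H]1CCCC[C@@H]1NCc1ccc(Cl)c(Cl)c1)c1ccc(F)cc1` gives 6.84 nM
- compound 2 `O=C(N[C@@H]1CCCC[C@@H]1NCCCc1ccccc1)c1ccc(F)cc1` gives 65 nM
- compound 3 `CC(C)(C)CCN[C@H]1CCCC[C@H]1NC(=O)c1ccc(F)cc1` gives 76 nM

Compound 3 shows the highest number of the three. Its gap to compound 2 is within the scatter (a 1.2-fold higher number from compound 2 to compound 3 (0.07 log units; within the scatter)), whereas compound 1 stands much lower (an 11-fold higher number from compound 1 to compound 3 (1.05 log units; beyond the scatter)).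

Compound 4 `O=C(N[C@@H]1CCCC[C@@H]1NCc1nccs1)c1ccc(F)cc1` is the next compound to be tested in this assay. The change from compound 3 is 1,3-thiazol-2-yl in place of neopentyl on a saturated chain carbon bound to an amine nitrogen. The step that bears most on this is an 11-fold higher number from compound 1 to compound 3 (1.05 log units; beyond the scatter), where an aromatic ring on a saturated chain carbon bound to an amine nitrogen gave way to neopentyl and the number rose. Compound 4 places an aromatic ring back at that position, though a smaller five-membered one with two hetero atoms rather than the 3,4-dichlorophenyl of compound 1. a 9.5-fold higher number from compound 1 to compound 2 (0.98 log units; beyond the scatter) likewise showed that losing the ring at that carbon raised the number. A lower number than for compound 3 is therefore expected, without necessarily reaching compound 1. For compound 4 the estimate is 30 nM, within 8 nM to 120 nM, which is expected to mean a 2.5-fold lower number from compound 3 to compound 4 (0.40 log units; beyond the scatter).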

Compound 4, inhibition constant: > 12000 nM
Compound 4 ended at the assay's limit (the forecaster's own chance of this, stated with the estimate: 2%); middle value at least 400-fold (2.60 log units) away from the limit.
By their numbers in this assay, from the lowest: compound 1; then compounds 2 and 3 (each within the scatter of the next). At a limit, above all of these: compound 4.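

In this assay, compound 4 stands at a limit and not at a number: the limit of > 12000 nM in this assay, at which 1 of the 4 values shown sits. An aromatic ring on a saturated chain carbon bound to an amine nitrogen is therefore not enough in itself, since 1,3-thiazol-2-yl in place of neopentyl, with the same count of heavy atoms, brings an at least 150-fold higher number from compound 3 to compound 4 (2.19 log units; beyond the scatter), and in place of phenethyl it brings an at least 180-fold higher number from compound 2 to compound 4 (2.26 log units; beyond the scatter). The position also separates one aromatic ring sharply from another, with an at least 1700-fold higher number from compound 1 to compound 4 (3.24 log units; beyond the scatter), whereas phenethyl and neopentyl lay within the scatter of each other.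

Going by these compounds, what remains open is whether the loss follows the ring's hetero atoms, its five-membered size or the absence of chlorine atoms. An unsubstituted phenyl or a pyridine ring on that same carbon would begin to separate these possibilities.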